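Swapping the aryl group on a camphor-derived hydrazide

The compounds below may be only part of what the source reports. "The series", "measured", "known", "first", "only" and "open" are said of these compounds alone.

Three hydrazides built on the same bicyclic core have been tested in an ADME assay on Vero cells (Chlorocebus sabaeus) for cytotoxicity, read by spectrophotometry, with a stated time of 4 days; on this read-out lower numbers stand for higher toxicity in this test and higher numbers for lower toxicity in this test. Compound 3 `CC1(C)[C@@H]2CC[C@@]1(C)/C(=N/NC(=O)c1ccccc1)C2`, which carries a phenyl on the carbonyl carbon, gives 1430000 nM and so stands highest of the two numbers that were actually read. Its nearest neighbour is compound 1 `CC1(C)[C@@H]2CC[C@@]1(C)/C(=N/NC(=O)c1cccs1)C2`, with a thiophen-2-yl in that place, which in this assay gives 363000 nM. Compound 2 `CC(=O)N/N=C1\C[C@H]2CC[C@]1(C)C2(C)C`, which carries a methyl on the carbonyl carbon, gives only a limit in this assay, namely > 250000 nM (the limit of > 250000 nM in this assay, at which 1 of the 3 values shown sits), so its steps to the other two compounds cannot be sized.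

Compound 4 `CC1(C)[C@@H]2CC[C@@]1(C)/C(=N/NC(=O)c1ccco1)C2` has not yet been measured. It differs from compound 3 in one place: furan-2-yl in place of phenyl on a carbonyl carbon. Among the compounds with values here, the one measured step that bears on this change is a 3.9-fold higher number from compound 1 to compound 3 (0.60 log units; beyond the scatter), where a six-membered aromatic ring of carbon only replaced a five-membered aromatic ring with one hetero atom. The present change runs the other way, from phenyl to a five-membered aromatic ring with one hetero atom, so a lower number of roughly that size is expected for compound 4, giving a 2.9-fold lower number from compound 3 to compound 4 (0.46 log units; beyond the scatter). The estimate for compound 4 in this assay is 500000 nM, with a range from 150000 nM to 1500000 nM.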

Compound 4, half-maximal cytotoxic concentration: 285000 nM
For compound 4 the middle estimate is 1.8-fold (0.24 log units) above the measured one; the range from low to high includes it.
By their numbers in this assay, from the lowest: compounds 4 and 1 (each within the scatter of the next); then compound 3.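

In this assay, furan-2-yl in place of phenyl on a carbonyl carbon gives a 5.0-fold lower number from compound 3 to compound 4 (0.70 log units; beyond the scatter), so compound 4 joins compound 1 as a second case in which a five-membered aromatic ring with one hetero atom reads lower than the phenyl of compound 3. The two five-membered rings themselves cannot be told apart here, since the step between them is a 1.3-fold lower number from compound 1 to compound 4 (0.11 log units; within the scatter), and among these three compounds the clear difference therefore lies between phenyl and either five-membered ring, not between furan-2-yl and thiophen-2-yl. Compound 2 gives only a limit, and its steps to the other compounds cannot be read: the limit of > 250000 nM in this assay, at which 1 of the 4 values shown sits.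

The compounds shown leave open whether the higher number of compound 3 belongs to six-membered aromatic rings in general or to phenyl alone, which a pyridin-2-yl group on the same carbonyl carbon would help to separate. From the compounds shown here alone, it also remains open how a saturated ring such as cyclohexyl, or a phenyl carrying a chlorine or a methoxy group, would read in this assay.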